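Cyclobutyl to oxolan-3-yl: expectation for compound 4

A few compounds are considered here, and "the series" means these few. Any claim that something is new, unique, unknown or untested is made for them only; others in the source may bear on it.

Of the compounds shown here, three have so far been read in a functional assay on CHO cells for antagonist activity at adenosine receptor A2b (Homo sapiens), read by 33P incorporation, with a stated time of 20 min; a lower number here means a stronger inhibitor, a higher number a weaker inhibitor. Compound 1 `Cn1c(-c2ccc(F)cc2)nc2c(NC3CCCC3)ncnc21` gives only a limit of the assay, > 30000 nM (the limit of > 30000 nM in this assay, at which 1 of the 3 values shown sits). Compound 2 `CCn1c(-c2ccccc2)nc2c(NC3CCCCC3)ncnc21` gives 9020 nM. Compound 3 `CCCn1c(-c2ccccc2)nc2c(NC3CCC3)ncnc21` gives 774 nM, the lowest of the two numbers, and its gap to compound 2 lies beyond the scatter. Compound 4 `CCCn1c(-c2ccccc2)nc2c(NC3CCOC3)ncnc21` is not yet measured. It differs from compound 3 by oxolan-3-yl in place of cyclobutyl on a nitrogen on an aromatic ring. Among the compounds with values here, no pair of measured compounds carries this change, so its size cannot be read from the series. A step of modest size, not clearly beyond the scatter, is expected, a 1.6-fold higher number from compound 3 to compound 4 (0.19 log units; within the scatter). Compound 4 is estimated at 1200 nM, within 400 nM to 4000 nM.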

Compound 4, inhibition constant: 9080 nM
For compound 4 the middle estimate is 7.6-fold (0.88 log units) below the measured one; measured number outside the range, above it.
By their numbers in this assay, from the lowest: compound 3; then compounds 2 and 4 (each within the scatter of the next). At a limit, above all of these: compound 1.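

Within the data shown here, this is the first pair that differs in one place, and it gives a direct read on the group on a nitrogen on an aromatic ring: with oxolan-3-yl in place of cyclobutyl, this assay shows a 12-fold higher number from compound 3 to compound 4 (1.07 log units; beyond the scatter). The position therefore does not tolerate this change, which replaces a four-membered ring of carbon only with a five-membered ring with one oxygen. Nothing available here bears on the cause of this step.

Ring size and the ring oxygen change together in this pair, so their separate contributions remain open. Oxetan-3-yl or pyrrolidin-3-yl at this position, on the core of compound 3, would bear on that question.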